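Propargyloxy handle on the saturated ring of compound 1

The source may report more compounds than this note shows. Statements on the series, on what has been measured and on what is new or still open speak of the compounds shown alone.

Compound 1, `O=C(N1CCCC[C@@H]1Cc1ccccc1)n1ncc(C(O)(c2ccc(F)cc2)c2ccc(F)cc2)n1`, is one of two measured compounds in an assay on cells for inhibition of diacylglycerol lipase-alpha (Mus musculus), with stated times of 20 min and 30 min; on this read-out higher numbers stand for weaker inhibition and lower numbers for stronger inhibition; in that setting compound 1 gives 3.02 nM, the lower of the two numbers. Its companion compound 2, `O=C(N1CCCC[C@@H]1Cc1ccccc1)n1cc(C(O)(c2ccc(F)cc2)c2ccc(F)cc2)nn1`, has the same core with the triazole attached through a different ring atom, and in this assay compound 2 gives 3.8 nM; the two values lie within the scatter of each other, so no order between them can be claimed.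

Compound 3, `C#CCO[C@@H]1CC[C@H](Cc2ccccc2)N(C(=O)n2ncc(C(O)(c3ccc(F)cc3)c3ccc(F)cc3)n2)C1`, has not yet been measured. It differs from compound 1 as follows: propargyloxy in place of hydrogen on a saturated ring carbon. Among the compounds with values here, no measured pair here shows the effect of adding a group on that saturated ring carbon, so the expectation rests on compound 1 alone. The author expects a step from compound 1 to compound 3 of a 1.7-fold higher number from compound 1 to compound 3 (0.22 log units; within the scatter), essentially none beyond the scatter. For compound 3 the estimate in this assay is therefore 5 nM, with a range from 1.5 nM to 20 nM.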

Compound 3, half-maximal inhibitory concentration: < 1 nM
Compound 3: only a limit was reported; the forecaster's own chance of this, stated with the estimate: 2%; middle value at least 5.0-fold (0.69 log units) away from the limit.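

The saturated ring carbon two ring bonds from the ring nitrogen tolerates a substituent in this assay: compound 3 gives < 1 nM, which is a limit of the assay and not a number. Putting propargyloxy in place of hydrogen there gives an at least 3.0-fold lower number from compound 1 to compound 3 (0.48 log units; beyond the scatter), a change at this position that the earlier pair, which differs only in how the triazole is attached, could not reveal. This step is a bound rather than a measured size: the limit of < 1 nM in this assay, at which 1 of the 3 values shown sits.

The compounds shown leave open whether a smaller group on the same carbon, such as methoxy or hydroxyl, or an amine there, would go with a similar step. They also leave open whether propargyloxy would give a comparable step on the core of compound 2.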